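The source may hold more compounds than are shown below. What is called first, only, known or untested is meant among the compounds shown, and "the series" means these compounds.

Measured so far in a functional assay on MCF7 cells (Homo sapiens) for antiproliferative activity, read by MTT assay, with a stated time of 72 h; a higher number here means a weaker inhibitor, a lower number a stronger inhibitor:
compound 1 `CCNC(=O)c1cc(Oc2ccc(NC(=O)c3nn(-c4cccc(F)c4)c(=O)cc3C)cc2)ccn1` gives 18900 nM
compound 2 `CCNC(=O)c1cc(Oc2ccc(NC(=O)c3nn(-c4ccccc4OC(F)(F)F)c(=O)cc3C)cc2)ccn1` gives 15500 nM
compound 3 `CCNC(=O)c1cc(Oc2ccc(NC(=O)c3nn(-c4cccc(C(F)(F)F)c4)c(=O)cc3C)cc2)ccn1` gives 40600 nM

Compound 3 holds the highest number of the three. The gap from compound 1 is a 2.1-fold higher number from compound 1 to compound 3 (0.33 log units; beyond the scatter) and from compound 2 it is a 2.6-fold higher number from compound 2 to compound 3 (0.42 log units; beyond the scatter); both are modest but beyond the scatter, while a 1.2-fold lower number from compound 1 to compound 2 (0.09 log units; within the scatter) stays within it, so compounds 1 and 2 cannot be ordered against each other.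

Compound 4 `CCNC(=O)c1cc(Oc2ccc(NC(=O)c3nn(-c4ccc(Br)cc4F)c(=O)cc3C)cc2)ccn1` is not yet measured. It differs from compound 3 in one place: 4-bromo-2-fluorophenyl in place of 3-(trifluoromethyl)phenyl on an aromatic nitrogen. The step that bears most directly is a 2.1-fold higher number from compound 1 to compound 3 (0.33 log units; beyond the scatter), where the trifluoromethyl on the aromatic carbon raised the number; compound 4 carries no trifluoromethyl but a fluoro and a bromo, so the step from compound 3 to compound 4 is expected to undo roughly that rise. The step of a 2.6-fold higher number from compound 2 to compound 3 (0.42 log units; beyond the scatter) points the same way. A modest lower number is therefore expected, a 1.9-fold lower number from compound 3 to compound 4 (0.29 log units; within the scatter), placing compound 4 near compound 1. The value of compound 4 in this assay is estimated at 21000 nM, with a range of 9000 nM to 50000 nM.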

Compound 4, half-maximal inhibitory concentration: 35100 nM
Estimate against measurement, compound 4: 1.7-fold (0.22 log units) below; measured number inside the range.
By their numbers in this assay, from the lowest: compounds 2, 1, 4 and 3 (each within the scatter of the next, the first and the last beyond it).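

In this assay, 4-bromo-2-fluorophenyl on the aromatic nitrogen cannot be separated from 3-(trifluoromethyl)phenyl, a 1.2-fold lower number from compound 3 to compound 4 (0.06 log units; within the scatter), so losing the trifluoromethyl does not by itself bring the number down. The same group also cannot be separated from 3-fluorophenyl, a 1.9-fold higher number from compound 1 to compound 4 (0.27 log units; within the scatter), and only 2-(trifluoromethoxy)phenyl stands clear of it, a 2.3-fold higher number from compound 2 to compound 4 (0.35 log units; beyond the scatter), a modest step that leaves all the changes at this position small so far. Nothing available explains why these aryl groups differ.

As far as these compounds go, all four compounds carry a fluorine-bearing phenyl group at this nitrogen, so it remains open whether an unsubstituted phenyl, a phenyl with an amine or carboxylic acid, or a plain alkyl chain would move the number further. The ethyl amide of the shared core also stays constant, leaving the effect of a longer chain or a free carboxylic acid there open.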